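Swapping the aryl substituent on a chromanol cyanoguanidine

This account rests on a few compounds, and the source may have more. Where it says the series, first, only, none or still open, it means among the compounds named here.

Measured so far:
compound 1, `CC1(C)Oc2ccc(C(=O)c3ccccc3)cc2[C@@H](/N=C(\NC#N)Nc2ccc(Cl)cc2)[C@@H]1O`, 7100 nM
compound 2, `CC1(C)Oc2ccc(C(=O)Nc3ccccc3)cc2[C@@H](/N=C(\NC#N)Nc2ccc(Cl)cc2)[C@@H]1O`, > 100000 nM

Two compounds share a chromanol core carrying a cyanoguanidine and differ only in the group on the aromatic ring of that core. In a functional assay (aorta) with Rattus norvegicus as the target (on this read-out higher numbers stand for weaker inhibition and lower numbers for stronger inhibition), compound 1 gives 7100 nM. Compound 2 reaches only the limit of the assay, > 100000 nM, so for compound 2 there is no number, just the statement that it lies at the limit of > 100000 nM in this assay, at which 1 of the 2 values shown sits. The step of an at least 14-fold higher number from compound 1 to compound 2 (1.14 log units; beyond the scatter) therefore shows that this position is sensitive to what is placed on it.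

Compound 3, `CC1(C)Oc2ccc(S(=O)(=O)N3CCOCC3)cc2[C@@H](/N=C(\NC#N)Nc2ccc(Cl)cc2)[C@@H]1O`, has not been measured. Its difference from compound 2 is (morpholin-4-yl)sulfonyl in place of phenylcarbamoyl on an aromatic carbon. Among the compounds with values here, no measured step involves a sulfonyl group, so the only guidance is that the same position moved by an at least 14-fold higher number from compound 1 to compound 2 (1.14 log units; beyond the scatter) when the group on it changed. Since compound 2 stands at a limit, the step of an at least 2.5-fold lower number from compound 2 to compound 3 (0.39 log units; beyond the scatter) is expected as an estimate only, towards a value between those of compounds 1 and 2. Compound 3 is estimated at 40000 nM, with a range from 8000 nM to 200000 nM.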

Compound 3, half-maximal inhibitory concentration: 3100 nM
Compound 3: middle estimate off by 13-fold (1.11 log units), on the high side; measured number outside the range, below it.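

In this assay, (morpholin-4-yl)sulfonyl gives a measurable value at the position where phenylcarbamoyl gave none, with an at least 32-fold lower number from compound 2 to compound 3 (1.50 log units; beyond the scatter). It also improves on the benzoyl group of compound 1, with a 2.3-fold lower number from compound 1 to compound 3 (0.36 log units; beyond the scatter), which makes compound 3 the strongest of the three shown, even though the step from compound 1 is modest and much smaller than the step from compound 2. The larger step can be read only as a minimum, because compound 2 stands at a limit of the assay rather than at a measured number: the limit of > 100000 nM in this assay, at which 1 of the 3 values shown sits.

The compounds shown do not separate the contribution of the sulfonyl group from that of the morpholine ring, and a dimethylaminosulfonyl or a methylsulfonyl group at the same aromatic carbon would be needed to tell these apart. They also leave open how a much smaller group, such as a nitrile or an acetyl group, would read at this place, and whether the order seen here would hold with a different group in place of the 4-chlorophenyl on the cyanoguanidine.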